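A few compounds are considered here, and "the series" means these few. Any claim that something is new, unique, unknown or untested is made for them only; others in the source may bear on it.

Measured compounds:
Compound 1 `C[C@H](Nc1nc2cc(Cl)c(F)cc2s1)c1ccccc1` — 58900 nM
Compound 2 `COc1ccc([C@H](C)Nc2nc3cc(Cl)c(F)cc3s2)cc1` — "not determined" (no result reported)
Compound 3 `Fc1cc2sc(N[C@@H]3CCCC[C@@H]3OCc3ccccc3)nc2cc1Cl` — 60800 nM

Three compounds share a common core and were examined in a functional assay on HeLa cells (Homo sapiens) for cytotoxicity, read by MTT assay, with a stated time of 24 h; a higher number here means a weaker inhibitor, a lower number a stronger inhibitor. Compound 1 gives 58900 nM in this assay, and compound 3 gives 60800 nM; these two values lie within the usual scatter of each other, so no order can be read between them. As far as these compounds go, compound 2, which carries a methoxy group on its phenyl ring, has no single number in this assay: its entry reads "not determined" (no result reported), so its own position on the scale is unknown.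

Compound 4 `C[C@H](Nc1nc2cc(Cl)c(F)cc2s1)c1ccc(F)cc1` has not yet been measured. It differs from compound 2 by the change (fluoro in place of methoxy on an aromatic carbon), that is, fluoro in place of methoxy on an aromatic carbon, para to a large group. For the measured compounds named here, no measured pair in this set shows such a step, so the size of the change cannot be taken from the data. The closest measured point of reference is compound 1, which carries no substituent at that position and gives 58900 nM. On that basis, compound 4 is expected to land near compound 1 and compound 3, with no step beyond the scatter in either direction. Compound 4 is therefore estimated at 55000 nM, with a range from 25000 nM to 120000 nM.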

Compound 4, half-maximal inhibitory concentration: 61900 nM
Estimate against measurement, compound 4: 1.1-fold (0.05 log units) below, and the stated range covers the measured number.
By their numbers in this assay, from the lowest: compounds 1, 3 and 4 (each within the scatter of the next).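

In this assay, the aromatic carbon para to a large group now has its first readable step, and fluoro in place of hydrogen there stays within the scatter (a 1.1-fold higher number from compound 1 to compound 4 (0.02 log units; within the scatter)). For the compounds shown here, this single step shows that a fluoro at this position leaves the number of compound 4 indistinguishable from that of compound 1, so the earlier compounds' values and this one form a single level on the scale. The step from methoxy to fluoro cannot be read, as compound 2 has no number, and no supporting measurement bears on why this result stands as it does.

As far as these compounds go, whether any group at this aromatic carbon can move the number beyond the scatter remains open, as the fluoro is the only substituent there with a value, and an amine or a carboxylic acid in that place could give a different reading. From the compounds shown here alone, it also remains open whether the methoxy of compound 2 or a longer chain in its place would sit at the same level as compound 1 and compound 4.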